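From compound 2 to compound 4: methoxy to hydroxy

The source may hold more compounds than are shown below. What is called first, only, known or untested is meant among the compounds shown, and "the series" means these compounds.

In a functional assay on MCF7 cells (Homo sapiens) for antiproliferative activity, read by sulforhodamine B assay, with a stated time of 48 h (a higher number here means a weaker inhibitor, a lower number a stronger inhibitor), compound 1 (`COc1ccc(C(=O)/C=C/c2ccccc2-c2ccc(F)cc2)cc1OC`) gives 7100 nM. Compound 2 (`COc1ccc(C(=O)/C=C/c2ccccc2-c2ccc(F)nc2)cc1OC`) gives 41000 nM, and 6-fluoropyridin-3-yl in place of 4-fluorophenyl accounts for a 5.8-fold higher number from compound 1 to compound 2 (0.76 log units; beyond the scatter). Compound 3 (`COc1cc(C(=O)/C=C/c2ccccc2-c2ccc(F)nc2)ccc1O`) gives 27000 nM, which is a 1.5-fold lower number from compound 2 to compound 3 (0.18 log units; within the scatter) for hydrogen in place of methyl on an oxygen on an aromatic ring. Compound 2 therefore stands level with compound 3 within the scatter and clearly apart from compound 1.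

Compound 4 (`COc1ccc(C(=O)/C=C/c2ccccc2-c2ccc(F)nc2)cc1O`) has not been measured. Its difference from compound 2 is hydrogen in place of methyl on an oxygen on an aromatic ring, which reads as methoxy to hydroxy. Within the data shown here, the closest precedent is compound 3, where the same exchange on the other methoxy group gave a 1.5-fold lower number from compound 2 to compound 3 (0.18 log units; within the scatter). The step to compound 2 from compound 1 involves a different part of the molecule and does not bear on this change. With a single precedent at a different oxygen, the evidence is thin, and no step beyond the scatter is expected in this assay. The estimated step is a 1.5-fold lower number from compound 2 to compound 4 (0.17 log units; within the scatter). For compound 4 the expected value is 28000 nM, with an estimated range from 12000 nM to 60000 nM.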

Compound 4, half-maximal inhibitory concentration: 2000 nM
Compound 4: middle estimate off by 14-fold (1.15 log units), on the high side; the whole stated range lies above it.
By their numbers in this assay, from the lowest: compound 4; then compound 1; then compounds 3 and 2 (each within the scatter of the next).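

In this assay, the exchange of methyl for hydrogen on an oxygen on an aromatic ring does not behave the same at the two methoxy groups: a 1.5-fold lower number from compound 2 to compound 3 (0.18 log units; within the scatter), whereas a 21-fold lower number from compound 2 to compound 4 (1.31 log units; beyond the scatter). The outcome of methoxy to hydroxy therefore depends on which oxygen carries it, and compound 3 alone gave no sign of this, while compound 4 also shows that the 6-fluoropyridin-3-yl group, present in both compound 2 and compound 4, can stand in a compound with a far lower number than compound 2. Nothing measured on these compounds accounts for the difference between the two oxygens.

Still open is whether the same exchange gives a step of similar size with 4-fluorophenyl in place of 6-fluoropyridin-3-yl, since the series shown holds only the methoxy forms of that group. Also open, on these data alone, is how far the hydrogen on this oxygen can be varied, for example whether an ethoxy group or an amine at the same place keeps the number of compound 4 or returns it towards that of compound 2.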